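Carboxy for Methoxy on the Pyridinyl Amine: Solubility Outlook

The compounds below may be only part of what the source reports. "The series", "measured", "known", "first", "only" and "open" are said of these compounds alone.

The measured compounds and their values:
compound 1 `COc1ccnc(Nc2cc3[nH]c(-c4cccc(C(F)(F)F)c4)nc3cn2)c1` — < 5000 nM
compound 2 `COc1ccc(Nc2cc3[nH]c(-c4cccc(C(F)(F)F)c4)nc3cn2)nc1` — < 5000 nM
compound 3 `O=C(O)c1ccc(Nc2cc3[nH]c(-c4cccc(C(F)(F)F)c4)nc3cn2)nc1` — < 5000 nM

In a physicochemical assay for solubility, using the shake flask method, measured as kinetic solubility, with a stated time of 20 h, at pH 2 (a lower number here means a less soluble compound, a higher number a more soluble compound), compound 1 gives < 5000 nM, which is a limit of the assay and not a number. Compound 2 likewise gives < 5000 nM, a limit. Compound 3 gives < 5000 nM, again a limit. All three values sit at one and the same limit (the limit of < 5000 nM in this assay, at which 3 of the 3 values shown sit), so compound 1 stands nowhere distinguishable from its two neighbours: the steps a step that the two limits leave unreadable from compound 1 to compound 2, a step that the two limits leave unreadable from compound 1 to compound 3 and a step that the two limits leave unreadable from compound 2 to compound 3 are all unreadable, their size hidden by the limit on both sides.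

Compound 4 `O=C(O)c1ccnc(Nc2cc3[nH]c(-c4cccc(C(F)(F)F)c4)nc3cn2)c1` is the next compound to be measured. Relative to compound 1 the change is carboxy in place of methoxy on an aromatic carbon. Among the compounds with values here, the measured step that bears most directly on it is the one from compound 2 to compound 3, the same exchange of carboxy for methoxy on an aromatic carbon of the ring, and that step could not be read. Since compound 3, which already carries a carboxy group, sits at the limit with < 5000 nM, no movement out of the limit is expected for compound 4. The expected step is a step that the limit leaves unreadable from compound 1 to compound 4. Compound 4 is therefore estimated at 2000 nM, with a range from 400 nM to 8000 nM, most likely reported again only as a limit.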

Compound 4, solubility: < 5000 nM
Compound 4: no number, only a limit; the forecaster's own chance of this, stated with the estimate: 80%; the middle value does not contradict the limit.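

In this assay compound 4 gives < 5000 nM, which is a limit of the assay and not a number. No new step can be read between compound 4 and compound 1, compound 2 or compound 3, since all four sit together: the limit of < 5000 nM in this assay, at which 4 of the 4 values shown sit.

The compounds shown leave open how far each lies from that limit, and whether exchanging methoxy for carboxy changes solubility at all.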